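This account rests on a few compounds, and the source may have more. Where it says the series, first, only, none or still open, it means among the compounds named here.

Measured in an assay on VSM-A10 cells for antagonist activity at Endothelin-1 receptor (Rattus norvegicus); a lower number here means a stronger inhibitor, a higher number a weaker inhibitor:
Compound 1 `Cc1noc(NS(=O)(=O)c2cccc([N+](=O)[O-])c2)c1C`: 7800 nM
Compound 2 `CCCNc1ccc(S(=O)(=O)Nc2onc(C)c2C)cc1`: 27000 nM
Compound 3 `Cc1noc(NS(=O)(=O)c2cccc3c(N(C)C)cccc23)c1[N+](=O)[O-]`: 17300 nM

Of the three, compound 2 carries the highest number. Compound 3 stands within the scatter of compound 2, so nothing separates them; compound 1 lies beyond the scatter, at the lower number. Compound 4 `Cc1noc(NS(=O)(=O)c2ccc(NCC(=O)O)cc2)c1C` has not been measured. Against compound 2 it shows (carboxy in place of ethyl on a saturated chain carbon bound to a nitrogen on an aromatic ring), carboxy in place of ethyl on a saturated chain carbon bound to a nitrogen on an aromatic ring. Going by the values given here, no measured pair carries this change, so its size in this assay is unknown. For compound 4 the expected step is a 1.8-fold lower number from compound 2 to compound 4 (0.26 log units; within the scatter), a modest move towards a lower number. Compound 4 is estimated at 15000 nM, with a range from 4000 nM to 60000 nM.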

Compound 4, half-maximal inhibitory concentration: 12000 nM
The estimate for compound 4 lay 1.3-fold (0.10 log units) above the measured number, and the stated range covers the measured number.
By their numbers in this assay, from the lowest: compounds 1, 4, 3 and 2 (each within the scatter of the next, the first and the last beyond it).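

Propylamino to (carboxymethyl)amino gives a 2.3-fold lower number from compound 2 to compound 4 (0.35 log units; beyond the scatter) in this assay and is the first change in one place that can be read in this set. Carboxy in place of ethyl on this saturated chain carbon is thus tolerated, with a modest gain rather than a loss. Nothing available here explains the shift.

As far as these compounds go, whether the carboxylic acid itself matters stays open, since a methyl ester, a primary amide or a longer chain ending in the acid would be needed to tell. This single pair also leaves open whether the same change would give a similar step on another core.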